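Adding a methyl to the amide of compound 3

The compounds below may be only part of what the source reports. "The series", "measured", "known", "first", "only" and "open" are said of these compounds alone.

- compound 1 `CCCCNC(=O)CCCOc1ccc(C(=O)c2c(CCCC)oc3ccccc23)cc1` gives > 50000 nM (a limit)
- compound 2 `CCCCc1oc2ccccc2c1C(=O)c1ccc(OCCCC(=O)N2CCCC2)cc1` gives 29900 nM
- compound 3 `CCCCc1oc2ccccc2c1C(=O)c1ccc(OCCCC(=O)NCc2ccccc2)cc1` gives 28900 nM

In a functional assay on HL-60 cells (Homo sapiens) for antiproliferative activity, read by MTT assay, with a stated time of 24 h (on this read-out higher numbers stand for weaker inhibition and lower numbers for stronger inhibition), compound 3 gives 28900 nM, level with compound 2, with a 1.0-fold lower number from compound 2 to compound 3 (0.01 log units; within the scatter). Compound 1 reports only a limit, > 50000 nM.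

Compound 4 `CCCCc1oc2ccccc2c1C(=O)c1ccc(OCCCC(=O)N(C)Cc2ccccc2)cc1` differs from compound 3 by methyl in place of hydrogen on an amide-type nitrogen. Among the measured compounds shown here, no measured step makes this exact change. The nearest is the swap of pyrrolidin-1-yl for benzylamino, a 1.0-fold lower number from compound 2 to compound 3 (0.01 log units; within the scatter). The other two, an at least 1.6-fold lower number from compound 1 to compound 2 (0.22 log units; that floor lies within the scatter) and an at least 1.7-fold lower number from compound 1 to compound 3 (0.23 log units; that floor lies within the scatter), are floors only. No step beyond the scatter is therefore expected in this assay, the expected step being a 1.0-fold higher number from compound 3 to compound 4 (0.02 log units; within the scatter). For compound 4 the estimated value is 30000 nM, with an expected range of 15000 nM to 50000 nM.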

Compound 4, half-maximal inhibitory concentration: > 50000 nM
Compound 4: only a limit was reported (the forecaster's own chance of this, stated with the estimate: 15%); middle value at least 1.6-fold (0.22 log units) from the limit.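

Among the compounds shown here, with methyl on the amide-type nitrogen, this assay shows for the first time a change at this position, an at least 1.7-fold higher number from compound 3 to compound 4 (0.23 log units; that floor lies within the scatter), while the swap of the whole amine part gives an at least 1.6-fold higher number from compound 2 to compound 4 (0.22 log units; that floor lies within the scatter). From the compounds shown here alone, both are floors, so the true size of the methyl change remains unknown, and the step from compound 1 to compound 4, with two limits, cannot be read. The reading of compound 4 is a limit, shared with compound 1: the limit of > 50000 nM in this assay, at which 2 of the 4 values shown sit.

What the compounds shown leave open is how an ethyl group or a longer chain on this nitrogen would read. So too is the effect of a carboxylic acid on the benzyl ring.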